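The compounds below may be only part of what the source reports. "The series", "measured", "known", "first", "only" and "open" are said of these compounds alone.

In a functional assay on LNCaP cells (Homo sapiens) for antiproliferative activity, read by propidium iodide staining, with a stated time of 96 h (on this read-out lower numbers stand for stronger inhibition and higher numbers for weaker inhibition), compound 1 `CC(O)(COc1cccc(C(F)(F)F)c1)C(=O)Nc1cccc(S(F)(F)(F)(F)F)c1` gives 28800 nM. Compound 2 `CC(O)(COc1ccccc1C(F)(F)F)C(=O)Nc1cccc(S(F)(F)(F)(F)F)c1` gives 26300 nM, which places it within the scatter of compound 1, so neither can be ranked above the other. Compound 3 `CC(O)(COc1ccccc1OC(F)(F)F)C(=O)Nc1cccc(S(F)(F)(F)(F)F)c1` has not yet been measured. It differs from compound 2 in a single place, trifluoromethoxy in place of trifluoromethyl on an aromatic carbon, ortho to a large group. Among the measured compounds shown here, only one measured step is available as a guide, a 1.1-fold lower number from compound 1 to compound 2 (0.04 log units; within the scatter). That step relocates the trifluoromethyl group and does not exchange it, so it bears on the new change only indirectly. For the measured compounds named here, no measured pair shows what trifluoromethoxy does in place of trifluoromethyl. Given how small that single step was, no shift beyond the scatter is expected in this assay, and neither direction is favoured. Compound 3 is therefore expected at about 25000 nM, with an estimated range of 11000 nM to 50000 nM. The expected change is a 1.1-fold lower number from compound 2 to compound 3 (0.02 log units; within the scatter).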

Compound 3, half-maximal inhibitory concentration: 16100 nM
Beside the measured number, compound 3's estimate is 1.6-fold (0.19 log units) above it; low and high end bracket the measured number.
By their numbers in this assay, from the lowest: compounds 3, 2 and 1 (each within the scatter of the next).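

In this assay, trifluoromethoxy in place of trifluoromethyl on an aromatic carbon, ortho to a large group, gives a 1.6-fold lower number from compound 2 to compound 3 (0.21 log units; within the scatter), so this first direct reading of the exchange, which brings in one oxygen and one hydrogen-bond acceptor, ranks neither compound above the other. Alongside the earlier move of the trifluoromethyl group, a 1.1-fold lower number from compound 1 to compound 2 (0.04 log units; within the scatter), it makes two single changes on this ring, and neither takes the number beyond the scatter, so no difference between these groups or these placements has yet been resolved in this series. Nothing available bears on why the numbers fall where they do.

The compounds shown leave open whether a group of another kind at this place, such as a nitrile, a chlorine or a methoxy, would move the number beyond the scatter. They also leave open how trifluoromethoxy behaves where compound 1 carries its trifluoromethyl group, and whether an amine in place of the hydroxyl on the shared core would matter more than either change seen here.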